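A few compounds are considered here, and "the series" means these few. Any claim that something is new, unique, unknown or untested is made for them only; others in the source may bear on it.

Compound 1 `COc1cc(-c2nn(-c3cccc(NC(=O)Nc4cc(C(F)(F)F)cc(C(F)(F)F)c4)c3)cc2-c2ccncc2)ccc1Cl` carries a methoxy group on one of its aromatic rings, and in a functional assay on SF-539 cells (Homo sapiens) for inhibition, read by sulforhodamine B assay, with a stated time of 48 h (a lower number here means a stronger inhibitor of growth, a higher number a weaker inhibitor of growth), compound 1 gives 829 nM. Its counterpart compound 2 `O=C(Nc1cccc(-n2cc(-c3ccncc3)c(-c3ccc(Cl)c(O)c3)n2)c1)Nc1cc(C(F)(F)F)cc(C(F)(F)F)c1`, in which the change is hydrogen in place of methyl on an oxygen on an aromatic ring, gives 765 nM in this assay; the step of a 1.1-fold lower number from compound 1 to compound 2 (0.03 log units; within the scatter) is small. Compound 3 `COc1cc(-c2nn(-c3cccc(NC(=O)Nc4ccc(Cl)c(C(F)(F)F)c4)c3)cc2-c2ccncc2)ccc1Cl` shares the same methoxy-bearing ring but differs from compound 1 in the urea-linked aryl group; the difference between the two cores is not broken down here. In this assay compound 3 gives 1650 nM, a number higher than that of compound 2, while its gap to compound 1 lies within the scatter. Compound 4 `O=C(Nc1cccc(-n2cc(-c3ccncc3)c(-c3ccc(Cl)c(O)c3)n2)c1)Nc1ccc(Cl)c(C(F)(F)F)c1` stands to compound 3 exactly as compound 2 stands to compound 1: the change is hydrogen in place of methyl on an oxygen on an aromatic ring, at the same place as before. Since the earlier step of a 1.1-fold lower number from compound 1 to compound 2 (0.03 log units; within the scatter) was within the scatter, the step of a 1.1-fold lower number from compound 3 to compound 4 (0.04 log units; within the scatter) is expected to be equally slight. On that basis compound 4 is estimated at 1500 nM in this assay, with a plausible range from 700 nM to 3200 nM.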

Compound 4, concentration for 50% growth inhibition: 782 nM
The estimate for compound 4 lay 1.9-fold (0.28 log units) above the measured number; the range from low to high includes it.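

In this assay, going from methoxy to hydroxy gives a 2.1-fold lower number from compound 3 to compound 4 (0.32 log units; beyond the scatter), a modest step on this core. Set beside the same change on the core of compound 1, the two steps cannot be told apart: the same change on two cores in this assay, a 1.1-fold lower number (0.03 log units; within the scatter) from compound 1 to compound 2 and a 2.1-fold lower number (0.32 log units; beyond the scatter) from compound 3 to compound 4, 1.9-fold (0.29 log units) apart, within the scatter of two such steps With only two pairs, this shows that the change can be carried between these two cores with no measurable difference in its step, but it does not show that the step is truly larger on the core of compound 3, nor that it would carry to a third core.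

The compounds shown leave open what would follow from replacing the hydroxy with an amine or a longer ether such as ethoxy, as only methoxy and hydroxy appear at this place. They also leave open whether the step would stay the same with another group on the urea-linked aryl ring, such as a nitrile in place of the trifluoromethyl.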